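Lengthening the ester chain at the assay limit

The source may report more compounds than this note shows. Statements on the series, on what has been measured and on what is new or still open speak of the compounds shown alone.

Of the compounds shown here, three have been measured in a functional assay on MCF7 cells (Homo sapiens) for antiproliferative activity; on this read-out higher numbers stand for weaker inhibition and lower numbers for stronger inhibition. Among the measured compounds shown here, compound 1 `O=C1NC(O)C(F)=CN1[C@H]1C=C[C@@H](CO)O1` gives 54100 nM, the only full number in the set. Compound 2 `Nc1nc(=O)n([C@H]2C=C[C@@H](CO)O2)cc1I` reads > 100000 nM, which is a limit and not a number. Compound 3 `CCCC(=O)OC[C@@H]1C=C[C@H](n2cc(F)c(N)nc2=O)O1` reads > 100000 nM, which is likewise a limit. Compound 3 therefore stands at the limit of > 100000 nM in this assay, at which 2 of the 3 values shown sit.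

Compound 4 `CCCCC(=O)OC[C@@H]1C=C[C@H](n2cc(F)c(N)nc2=O)O1` differs from compound 3 by methyl in place of hydrogen on a saturated chain carbon, three bonds along the chain from a carbonyl carbon. Cut one bond further out, the same difference reads propyl to butyl.

For the measured compounds named here, no measured pair in the set differs in one place, so no direct precedent exists for the size of this step. In this assay no step beyond the scatter is expected, and neither direction is favoured. Compound 3 gives only the limit > 100000 nM, so compound 4 is expected to read at that same limit, with a full number the less likely outcome. The expected change is a number no higher from compound 3 to compound 4 (the limit leaves the size open). The estimate for compound 4 is 100000 nM, with an expected range of 50000 nM to 150000 nM.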

Compound 4, half-maximal inhibitory concentration: > 100000 nM
Compound 4 ended at the assay's limit; the forecaster's own chance of this, stated with the estimate: 80%; the middle value sits exactly at the limit.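

In this assay compound 4 reads > 100000 nM as a limit and not a number. Compound 3 sits at a limit as well, so no step can be read from compound 3 to compound 4, and both stand here: the limit of > 100000 nM in this assay, at which 3 of the 4 values shown sit.

The compounds shown leave open whether going from propyl to butyl on the ester chain changes the read-out at all, and by how much.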